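The source may report more compounds than this note shows. Statements on the series, on what has been measured and on what is new or still open speak of the compounds shown alone.

Working notes on the series. Three compounds have a number in an assay on NIH3T3 cells with Urotensin-2 receptor (Homo sapiens) as the target (a higher number here means that more compound is needed for the effect, a lower number that less compound is needed), so far, all on the shared core, differing in the linker and the aryl group attached to it. Compound 1 `Cc1ccc(C)c(C(=O)NC(CCN(C)C)c2ccc(Cl)cc2)c1` carries an amide, and in this assay compound 1 gives 2880 nM. Compound 2 `CN(C)CCC(OC(=O)Nc1ccc2ccccc2c1)c1ccc(Cl)cc1` carries a carbamate, and in this assay compound 2 gives 525 nM. Compound 3 `CN(C)CCC(NC(=O)Nc1ccc(C(F)(F)F)cc1)c1ccc(Cl)cc1` carries a urea, and in this assay compound 3 gives 117 nM, the lowest of the three numbers; compound 2 sits above it and compound 1 further above, both gaps beyond the scatter.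

Compound 4 `CN(C)CCC(NC(=O)Nc1ccc(Oc2ccccc2)cc1)c1ccc(Cl)cc1` keeps the urea of compound 3 and differs in one place: phenoxy in place of trifluoromethyl on an aromatic carbon. Going by the values given here, no measured pair shows this exchange, so there is nothing to set its size against. Taking compound 3 with 117 nM as the reference, the step is expected to be small, a 1.3-fold lower number from compound 3 to compound 4 (0.11 log units; within the scatter), within or close to the scatter and if anything toward a lower number. Compound 4 is therefore estimated at 90 nM, with a range of 25 nM to 400 nM.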

Compound 4, half-maximal effective concentration: 110 nM
Beside the measured number, compound 4's estimate is 1.2-fold (0.09 log units) below it; low and high end bracket the measured number.
By their numbers in this assay, from the lowest: compounds 4 and 3 (each within the scatter of the next); then compound 2; then compound 1.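

Going by these compounds alone, with the urea kept, compounds 3 and 4 form the first pair that differs in one place, and in this assay the exchange gives a 1.1-fold lower number from compound 3 to compound 4 (0.03 log units; within the scatter). On this aromatic carbon, para to a large group, phenoxy with its 7 heavy atoms and six-membered aromatic ring thus stands in for trifluoromethyl with its 4 heavy atoms and no ring, and the two numbers remain within the scatter of each other. No measurement at hand bears on why these two groups read alike.

On these data alone, whether the same position would accept an amine, a carboxylic acid or a plain hydrogen stays open. The compounds shown also hold no pair that separates the urea from the amide or the carbamate with the aryl group held fixed, so the contribution of the linker cannot be read.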